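This account rests on a few compounds, and the source may have more. Where it says the series, first, only, none or still open, it means among the compounds named here.

Measured in a functional assay on RKO cells (Homo sapiens) for cytotoxicity, read by resazurin assay, with a stated time of 72 h; on this read-out higher numbers stand for weaker inhibition and lower numbers for stronger inhibition:
- Compound 1 `Cc1cn(-c2csc(Nc3ccc(Br)cc3)n2)c(C)n1`: 400 nM
- Compound 2 `Cc1nccn1-c1csc(Nc2cccc(Br)c2)n1`: > 100000 nM
- Compound 3 `Cc1nc2ccccc2n1-c1csc(Nc2ccc(Br)cc2)n1`: 90 nM

Compound 2 gives > 100000 nM, which is a limit of the assay, not a number. Of the two true numbers, compound 1 holds the higher one at 400 nM, a gap beyond the usual scatter from compound 3.

Compound 4 `Cc1nccn1-c1csc(Nc2ccc(Br)cc2)n1` has hydrogen in place of methyl on an aromatic carbon of a five-membered aromatic ring with 2 nitrogen (hydrogen in place of methyl on an aromatic carbon). Compound 3, also altered on this side of the molecule, still gives 90 nM, so only a modest shift seems likely here. The expected step of a 2.3-fold higher number from compound 1 to compound 4 (0.35 log units; beyond the scatter) is small, leaning towards weaker inhibition. For compound 4 the estimated value is 900 nM, with an expected range from 200 nM to 5000 nM.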

Compound 4, half-maximal inhibitory concentration: 30000 nM
Estimate against measurement, compound 4: 33-fold (1.52 log units) below; measured number above the stated range.
By their numbers in this assay, from the lowest: compound 3; then compound 1; then compound 4. At a limit, above all of these: compound 2.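

In this assay, hydrogen in place of methyl on an aromatic carbon gives a 75-fold higher number from compound 1 to compound 4 (1.88 log units; beyond the scatter), a large step for the loss of a single carbon. Going by these compounds alone, this single methyl therefore matters greatly to the cytotoxicity of compound 1, which the earlier compounds could not show, since none of them differed from compound 1 in this one place alone. Nothing measured here accounts for the size of this step. Among the compounds shown, this carbon carries only methyl or hydrogen, so what an ethyl group or an amine would do there stays open.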